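A few compounds are considered here, and "the series" means these few. Any claim that something is new, unique, unknown or untested is made for them only; others in the source may bear on it.

Series notes. Compound 1 `CC(C)=CC(=O)Nc1cccc(Oc2nc(Nc3ccn(C)n3)nc3c2CSCC3)c1` gives 44200 nM in a functional assay on A549 cells (Homo sapiens) for antiproliferative activity, read by MTT assay, with a stated time of 72 h; on this read-out lower numbers stand for stronger inhibition and higher numbers for weaker inhibition. Compound 2 `CC(C)/C=C/C(=O)Nc1cccc(Oc2nc(Nc3ccn(C)n3)nc3c2CSCC3)c1` carries the change (3-methylbut-1-en-1-yl in place of 2-methylprop-1-en-1-yl on a carbonyl carbon); in this assay compound 2 gives 33500 nM, and the step is a 1.3-fold lower number from compound 1 to compound 2 (0.12 log units; within the scatter). Compound 3 `COc1ccc(Nc2nc3c(c(Oc4cccc(NC(=O)C=C(C)C)c4)n2)CSCC3)cc1` differs from compound 1 in the core, (4-methoxyphenyl in place of 1-methyl-1H-pyrazol-3-yl on a nitrogen on an aromatic ring); in this assay compound 3 gives 26900 nM, and the step is a 1.6-fold lower number from compound 1 to compound 3 (0.22 log units; within the scatter). Compound 3 holds the lowest of the three numbers, nearest to compound 2 and furthest from compound 1, but both gaps lie within the scatter, so none of the three is called more or less potent than another.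

Compound 4 `COc1ccc(Nc2nc3c(c(Oc4cccc(NC(=O)/C=C/C(C)C)c4)n2)CSCC3)cc1` has not yet been measured. It differs from compound 3 by 3-methylbut-1-en-1-yl in place of 2-methylprop-1-en-1-yl on a carbonyl carbon, which is the same change already made from compound 1 to compound 2, now carried out on the core of compound 3 instead of the core of compound 1; the place of the change is the same in both pairs. Because a 1.3-fold lower number from compound 1 to compound 2 (0.12 log units; within the scatter) was small, compound 4 is expected to sit close to compound 3, the expected step being a 1.3-fold lower number from compound 3 to compound 4 (0.11 log units; within the scatter). Compound 4 is expected to give about 21000 nM in this assay, estimated to fall between 9000 nM and 45000 nM.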

Compound 4, half-maximal inhibitory concentration: 25900 nM
Estimate against measurement, compound 4: 1.2-fold (0.09 log units) below; low and high end bracket the measured number.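

In this assay, the new step for 3-methylbut-1-en-1-yl in place of 2-methylprop-1-en-1-yl on a carbonyl carbon is a 1.0-fold lower number from compound 3 to compound 4 (0.02 log units; within the scatter), and it agrees with the step on the other core: the same change on two cores in this assay, a 1.3-fold lower number (0.12 log units; within the scatter) from compound 1 to compound 2 and a 1.0-fold lower number (0.02 log units; within the scatter) from compound 3 to compound 4, 1.3-fold (0.10 log units) apart, within the scatter of two such steps. The step for 4-methoxyphenyl in place of 1-methyl-1H-pyrazol-3-yl on a nitrogen on an aromatic ring, now read with the 3-methylbut-1-en-1-yl group in place, is a 1.3-fold lower number from compound 2 to compound 4 (0.11 log units; within the scatter), and it agrees in the same way: the same change on two cores in this assay, a 1.6-fold lower number (0.22 log units; within the scatter) from compound 1 to compound 3 and a 1.3-fold lower number (0.11 log units; within the scatter) from compound 2 to compound 4, 1.3-fold (0.10 log units) apart, within the scatter of two such steps. Each of these steps lies within the scatter, so the series shows that neither change moves the number measurably on either core, not that a real effect of either change carries from one core to another.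

Going by these compounds, whether a different group on the carbonyl carbon, such as a dimethylamino-bearing chain or a longer alkyl chain, would give a step beyond the scatter remains open. The same holds for a group on the nitrogen such as a phenyl ring bearing a carboxylic acid or an amine.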